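Triazole Substituent Exchange Toward an Indolyl Analogue

This account rests on a few compounds, and the source may have more. Where it says the series, first, only, none or still open, it means among the compounds named here.

Compound 3 `O[C@H](COCCOC[C@@H](O)Cc1cn(Cc2ccc(C(F)(F)F)cc2)nn1)Cc1ccc(-c2ccccc2)cc1` is the reference point. In a functional assay on SGC-7901 cells (Homo sapiens) for inhibition, read by MTT assay, with a stated time of 72 h (on this read-out higher numbers stand for weaker inhibition of growth and lower numbers for stronger inhibition of growth), compound 3 gives 8700 nM, the lowest of the three numbers, though its separation from the other two stays within the scatter. Compound 1 `O[C@H](COCCOC[C@@H](O)Cc1cn(Cc2ccc3ccccc3c2)nn1)Cc1ccc(-c2ccccc2)cc1` gives 12100 nM in this assay, and compound 2 `O=C1COc2ccc(-n3cc(C[C@H](O)COCCOC[C@@H](O)Cc4ccc(-c5ccccc5)cc4)nn3)cc2N1` gives 15200 nM. The steps to compound 3 are small: a 1.4-fold lower number from compound 1 to compound 3 (0.14 log units; within the scatter) and a 1.7-fold lower number from compound 2 to compound 3 (0.24 log units; within the scatter).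

Compound 4 `O[C@H](COCCOC[C@@H](O)Cc1cn(-c2ccc3[nH]ccc3c2)nn1)Cc1ccc(-c2ccccc2)cc1` differs from compound 3 in one place: 1H-indol-5-yl in place of 4-(trifluoromethyl)benzyl on an aromatic nitrogen. Going by the values given here, the steps that bear on this exchange are the two that already swapped the group on the same aromatic nitrogen. The first is a 1.3-fold higher number from compound 1 to compound 2 (0.10 log units; within the scatter), in which a ring-bearing group took the place of a naphthalen-2-ylmethyl group; the second is a 1.7-fold lower number from compound 2 to compound 3 (0.24 log units; within the scatter). Both lie within the scatter, and no exchange at this position has so far moved the number beyond it. Compound 4 is therefore expected to show no step beyond the scatter, a 1.2-fold higher number from compound 3 to compound 4 (0.08 log units; within the scatter). On that basis compound 4 is estimated at 10500 nM in this assay, with a range from 4500 nM to 25000 nM.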

Compound 4, concentration for 50% growth inhibition: 45600 nM
Estimate against measurement, compound 4: 4.3-fold (0.64 log units) below; measured number outside the range, above it.
By their numbers in this assay, from the lowest: compounds 3, 1 and 2 (each within the scatter of the next); then compound 4.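

In this assay the position on the aromatic nitrogen is not indifferent to every exchange: 1H-indol-5-yl gives the first step there beyond the scatter, with a 5.2-fold higher number from compound 3 to compound 4 (0.72 log units; beyond the scatter) as the largest, alongside a 3.8-fold higher number from compound 1 to compound 4 (0.58 log units; beyond the scatter) and a 3.0-fold higher number from compound 2 to compound 4 (0.48 log units; beyond the scatter) in the same direction. Compound 4 therefore stands apart as the weakest of the four, while compounds 1, 2 and 3 remain within the scatter of one another despite their different groups. Having a ring directly on the aromatic nitrogen does not by itself separate compound 4 from the others, as compound 2 also has this arrangement and stays with compounds 1 and 3, which carry a methylene link.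

Still open, going by these compounds, is whether the ring hydrogen on the indole nitrogen or the missing link counts here: a 1-methyl-1H-indol-5-yl group and a (1H-indol-5-yl)methyl group on the same aromatic nitrogen would pull these two apart. Nothing available gives a reason for the higher number of compound 4.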